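The source may report more compounds than this note shows. Statements on the series, on what has been measured and on what is new or still open speak of the compounds shown alone.

Compound 1 `COc1ccc(-c2cnc(NC(=O)c3ccco3)n2C)cc1`: > 100000 nM (a limit)
Compound 2 `COc1ccc(-c2cnc(NC(=O)c3ccc(F)cc3)n2C)cc1`: >= 50000 nM (a limit)
Compound 3 `COc1ccc(-c2cnc(NC(=O)c3cccc(Br)c3)n2C)cc1`: > 100000 nM (a limit)

All three compounds were tested in a toxicity assay on THP-1 cells (Homo sapiens) for inhibition (on this read-out higher numbers stand for lower toxicity in this test and lower numbers for higher toxicity in this test), and none yields a number. Compound 3 stands at > 100000 nM, which is a limit. Compound 4 `COc1ccc(-c2cnc(NC(=O)c3ccccc3OC)n2C)cc1` carries 2-methoxyphenyl in place of 3-bromophenyl on a carbonyl carbon. Three measured steps involve the same place, namely a step that the two limits leave unreadable from compound 1 to compound 2, a step that the two limits leave unreadable from compound 1 to compound 3 and a step that the two limits leave unreadable from compound 2 to compound 3. None has a readable size, so they point in no direction. The expected step is therefore a number no higher from compound 3 to compound 4 (the limit leaves the size open), with nothing expected beyond the scatter. Compound 4 is estimated at 100000 nM, with an expected range from 50000 nM to 200000 nM.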

Compound 4, half-maximal cytotoxic concentration: > 100000 nM
Compound 4: a limit, no number; the forecaster's own chance of this, stated with the estimate: 85%; the middle value lies on the limit itself.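

The steps from compound 1, compound 2 and compound 3 to compound 4 cannot be read in this assay, since all four values are limits. The compounds shown leave open whether changing this group alters toxicity at all.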